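This account rests on a few compounds, and the source may have more. Where it says the series, first, only, none or still open, it means among the compounds named here.

Within the data shown here, compound 1 `CCCc1nnc(SCC(=O)c2ccc(C)cc2)n1N1C(=O)c2ccccc2C1=O` and compound 2 `COc1cc(-c2nnc(SCC(=O)c3ccc(Cl)cc3)n2N2C(=O)c3ccccc3C2=O)cc(OC)c1OC` share a core but differ from each other in two places, so no single step joins them. In a functional assay on A549 cells (Homo sapiens) for cytotoxicity, read by MTT assay, with a stated time of 48 h (on this read-out higher numbers stand for weaker inhibition and lower numbers for stronger inhibition), compound 1 gives only a limit of the assay, > 200000 nM. Among the measured compounds shown here, compound 2 in this assay gives 9030 nM, the only actual number among the two values shown. The other value shown is the limit of > 200000 nM in this assay, at which 1 of the 2 values shown sits. Compound 3 `COc1cc(-c2nnc(SCC(=O)c3ccc(C)cc3)n2N2C(=O)c3ccccc3C2=O)cc(OC)c1OC` has not yet been measured. It differs from compound 2 by methyl in place of chloro on an aromatic carbon. For the measured compounds named here, no measured pair of compounds shows this change on its own; the step from compound 2 to compound 3 is expected to be small, a 1.3-fold higher number from compound 2 to compound 3 (0.12 log units; within the scatter), a slight weakening at most and possibly nothing beyond the usual scatter. Compound 3 is therefore estimated at 12000 nM in this assay, expected to fall between 4000 nM and 40000 nM.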

Compound 3, half-maximal inhibitory concentration: 6760 nM
Beside the measured number, compound 3's estimate is 1.8-fold (0.25 log units) above it; measured number inside the range.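

In this assay, methyl in place of chloro on this aromatic carbon, para to a large group, gives a 1.3-fold lower number from compound 2 to compound 3 (0.13 log units; within the scatter), so this position takes either group without a change that can be told from the scatter. Among these compounds, the first single-place comparison at the other site, 3,4,5-trimethoxyphenyl in place of propyl, gives an at least 29-fold lower number from compound 1 to compound 3 (1.47 log units; beyond the scatter), a far larger effect than the swap of chloro for methyl. Compound 1 gives only a limit of the assay, so this step is a minimum: the limit of > 200000 nM in this assay, at which 1 of the 3 values shown sits.

Only chloro and methyl are seen on this carbon, so a methoxy, an amine or a carboxylic acid there could behave differently. From the compounds shown here alone, it also stays open whether the whole 3,4,5-trimethoxyphenyl is needed, or whether a plain phenyl or a longer chain in place of propyl would serve as well.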